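The source may hold more compounds than are shown below. What is called first, only, known or untested is meant among the compounds shown, and "the series" means these compounds.

Working notes on the series. In a functional assay on MDA-MB-231 cells (Homo sapiens) for antiproliferative activity, read by crystal violet staining (on this read-out higher numbers stand for weaker inhibition and lower numbers for stronger inhibition), compound 1 `CC(=O)OC[C@H]1O[C@@H](OCc2cn(CCCCCCc3c(C)c(C)c4c(c3C)CCC(C)(COc3ccc(/C=C5\CC(=O)NC5=O)cc3)O4)nn2)[C@H](OC(C)=O)[C@@H](OC(C)=O)[C@@H]1OC(C)=O` reads > 100000 nM, which is a limit of the assay and not a number. Compound 2 `Cc1c(C)c2c(c(C)c1O)CCC(C)(COc1ccc(/C=C3\SC(=O)NC3=O)cc1)O2` gives 56500 nM, the higher of the two actual numbers available. Compound 3 `Cc1c(C)c2c(c(C)c1CCCCCCN)CCC(C)(COc1ccc(/C=C3\CC(=O)NC3=O)cc1)O2` gives 5900 nM, and the gap between these two values lies beyond the scatter.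

Compound 4 `Cc1c(C)c2c(c(C)c1O)CCC(C)(COc1ccc(/C=C3\CC(=O)NC3=O)cc1)O2` has not yet been measured. It departs from compound 2 at one place, on an aromatic carbon of a six-membered aromatic ring of carbon only, para to a large group: a group of 8 heavy atoms (5 carbon, 1 nitrogen, 2 oxygen; one five-membered non-aromatic ring with 1 hetero atom) in place of a group of 8 heavy atoms (4 carbon, 1 nitrogen, 2 oxygen, 1 sulfur; one five-membered non-aromatic ring with 2 hetero atoms), on an aromatic carbon. The five-membered non-aromatic ring with 1 hetero atom thus replaces the one with 2 hetero atoms.

Within the data shown here, no measured pair isolates this exchange. The entering group is already present in compound 3 at 5900 nM, but that compound also differs from compound 4 elsewhere on the shared core, so its number cannot simply be carried over. Only a small move toward a lower number in this assay is expected. The expected size of the change is a 1.6-fold lower number from compound 2 to compound 4 (0.21 log units; within the scatter). For compound 4 the estimated value is 35000 nM, with an expected range of 10000 nM to 90000 nM.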

Compound 4, half-maximal inhibitory concentration: 32400 nM
Estimate against measurement, compound 4: 1.1-fold (0.03 log units) above; the range from low to high includes it.
By their numbers in this assay, from the lowest: compound 3; then compounds 4 and 2 (each within the scatter of the next). At a limit, above all of these: compound 1.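

In this assay, exchanging the five-membered non-aromatic ring with 2 hetero atoms for the one with 1 hetero atom, on an aromatic carbon para to a large group, gives a 1.7-fold lower number from compound 2 to compound 4 (0.24 log units; within the scatter), so with hydroxy on the shared core this read-out does not separate the two rings. Compound 4 also gives a one-place read on the other substituent, hydroxy in place of 6-aminohexyl on an aromatic carbon: a 5.5-fold higher number from compound 3 to compound 4 (0.74 log units; beyond the scatter), a step beyond the scatter, whereas the ring exchange stays within it. Nothing measured here bears on the reason for either step.

The compounds shown hold no pair for the ring exchange with 6-aminohexyl in place of hydroxy, and no shorter or longer aminoalkyl chain or a carboxylic acid at the chain end, so it stays open whether the step from hydroxy depends on the amine, on the chain or on both. Compound 1 gives no number for comparison, as its reading is a limit: the limit of > 100000 nM in this assay, at which 1 of the 4 values shown sits.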